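From methoxy to hydroxy on compound 2

This account rests on a few compounds, and the source may have more. Where it says the series, first, only, none or still open, it means among the compounds named here.

Compound 1 `COc1ccc(-c2cc3ccc(OC)c(CCC(C)C)c3oc2=O)cc1OC` gives > 50000 nM (a limit)
Compound 2 `COc1ccc2cc(-c3ccc(C(F)(F)F)cc3)c(=O)oc2c1CCC(C)C` gives 38100 nM

For the measured compounds named here, both values come from a functional assay on MDA-MB-231 cells (Homo sapiens) for inhibition, read by MTT assay (a higher number here means a weaker inhibitor, a lower number a stronger inhibitor), and are the only measurements so far. The value of compound 1 is a limit of the assay and not a number. Going by the values given here, that leaves compound 2 at 38100 nM as the only measured number, and it marks a weak inhibitor.

Compound 3 `CC(C)CCc1c(O)ccc2cc(-c3ccc(C(F)(F)F)cc3)c(=O)oc12` differs from compound 2 in one place: hydrogen in place of methyl on an oxygen on an aromatic ring, or methoxy to hydroxy. Among the compounds with values here, no measured pair shows this change, so the expectation rests only on compound 2 at 38100 nM and is uncertain. A modest gain in strength is expected, amounting to a 2.1-fold lower number from compound 2 to compound 3 (0.33 log units; beyond the scatter) in this assay and possibly no more than the scatter. For compound 3 the estimated value is 18000 nM, with an expected range of 6000 nM to 50000 nM once measured.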

Compound 3, half-maximal inhibitory concentration: > 50000 nM
Compound 3 ended at the assay's limit; the forecaster's own chance of this, stated with the estimate: 15%; at least 2.7-fold (0.44 log units) between middle value and limit.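

Going from methoxy to hydroxy on compound 2 brought no gain: the change gives an at least 1.3-fold higher number from compound 2 to compound 3 (0.11 log units; that floor lies within the scatter) in this assay, so the lower number expected for the free hydroxy did not appear. Compound 3 gives > 50000 nM, and this is a limit of the assay and not a number. This first measured pair at the oxygen on the aromatic ring therefore sets only a floor on the step, and how far the number rises cannot be read from it, with most of the series sitting at that ceiling: the limit of > 50000 nM in this assay, at which 2 of the 3 values shown sit.

As far as these compounds go, what remains open is whether an ethyl or a longer chain ending in an amine on this oxygen would give a lower number than compound 2. From the compounds shown here alone, it is equally open how a carboxylic acid in place of the trifluoromethyl would read in this assay here.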